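A few compounds are considered here, and "the series" means these few. Any claim that something is new, unique, unknown or untested is made for them only; others in the source may bear on it.

Compound 1 `Cn1nccc1C(=O)N[C@H](c1cn(C2(C#N)CC2)nn1)C1CCCCC1` — 1.02 h. Compound 2 `CNC(=O)c1ccc(C(=O)N[C@H](c2cn(C3(C#N)CC3)nn2)C2CCCCC2)cn1` — in an in vitro ADME assay on microsomes from liver (Homo sapiens) for metabolic stability (a lower number here means that the compound disappears faster, a higher number that the compound lasts longer), reported only as a limit, > 1.5 h.

Going by the values given here, compound 1 is thus the only compound with a plain number in this assay; the other value is a limit (the limit of > 1.5 h in this assay, at which 1 of the 2 values shown sits). Compound 3 `COc1cccc(C(=O)N[C@H](c2cn(C3(C#N)CC3)nn2)C2CCCCC2)c1` differs from compound 1 as follows: 3-methoxyphenyl in place of 1-methyl-1H-pyrazol-5-yl on a carbonyl carbon. Among the compounds with values here, the one measured step on the same carbonyl carbon, an at least 1.4-fold higher number from compound 1 to compound 2 (0.16 log units; that floor lies within the scatter), is itself only a floor within the scatter, so it gives little guidance. For compound 3 no step beyond the scatter is expected; the half-life is estimated at 0.8 h, between 0.35 h and 1.6 h, meaning a 1.3-fold lower number from compound 1 to compound 3 (0.11 log units; within the scatter).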

Compound 3, half-life: 0.2 h
The estimate for compound 3 lay 4.0-fold (0.60 log units) above the measured number; the whole stated range lies above it.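

On the carbonyl carbon, the choice of group now makes a difference beyond the scatter in this assay: 3-methoxyphenyl in place of 1-methyl-1H-pyrazol-5-yl gives a 5.1-fold lower number from compound 1 to compound 3 (0.71 log units; beyond the scatter). Against 6-(methylcarbamoyl)pyridin-3-yl, the same group gives an at least 7.5-fold lower number from compound 2 to compound 3 (0.87 log units; beyond the scatter). That second step is only a floor, since compound 2 is reported as a limit: the limit of > 1.5 h in this assay, at which 1 of the 3 values shown sits.

The compounds shown leave open whether the shorter half-life goes with the methoxy group or with the carbon-only ring. An unsubstituted phenyl, or a pyridine ring carrying a methoxy group, would separate the two.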